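Hydrazone aryl swap on the adenosine-series core

This account rests on a few compounds, and the source may have more. Where it says the series, first, only, none or still open, it means among the compounds named here.

For the measured compounds named here, compound 1 `Nc1nc(N/N=C/c2cccnc2Cl)nc2c1ncn2[C@@H]1O[C@H](CO)[C@@H](O)[C@H]1O` is the only member with a number in an assay on CHO-K1 cells for displacement of a labelled ligand from adenosine receptor A1 (Homo sapiens), read by scintillation counting, with a stated time of 60 min; on this read-out higher numbers stand for weaker inhibition and lower numbers for stronger inhibition: compound 1 gives 4.6 nM. Compound 2 `COc1cc(/C=N/Nc2nc(N)c3ncn([C@@H]4O[C@H](CO)[C@@H](O)[C@H]4O)c3n2)cc(OC)c1OC` is also in the set; in this assay compound 2 gives only a limit, > 10000 nM, which is a limit of the assay and not a number (the limit of > 10000 nM in this assay, at which 1 of the 2 values shown sits). Going by the values given here, no step between two measured compounds is available, so the pair of compound 1 and compound 2 shows only that one aryl hydrazone gives a number and another gives a limit.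

Compound 3 `Nc1nc(N/N=C/c2ccc(-n3ccnc3)cc2)nc2c1ncn2[C@@H]1O[C@H](CO)[C@@H](O)[C@H]1O` is not yet measured. It differs from compound 1 as follows (4-(1H-imidazol-1-yl)phenyl in place of 2-chloropyridin-3-yl on a carbon with a double bond to nitrogen). The hydrazone carbon keeps its double-bonded nitrogen neighbour; only the aryl group changes. Given that compound 2 returns a limit and compound 1 a number, compound 3 is expected to lose potency, with an estimated step of a 65-fold higher number from compound 1 to compound 3 (1.81 log units; beyond the scatter) that is beyond the scatter. For compound 3 the estimate is 300 nM, spanning 30 nM to 5000 nM.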

Compound 3, inhibition constant: > 10000 nM
Compound 3 gave a limit, no number; the forecaster's own chance of this, stated with the estimate: 20%; at least 33-fold (1.52 log units) between middle value and limit.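

In this assay compound 3 gives > 10000 nM, which is a limit of the assay and not a number. For the compounds shown here, the first step that can be read is an at least 2100-fold higher number from compound 1 to compound 3 (3.33 log units; beyond the scatter), so on this carbon with a double bond to nitrogen, 4-(1H-imidazol-1-yl)phenyl in place of 2-chloropyridin-3-yl removes the measurable inhibition of compound 1 while the rest of the molecule stays the same. Going by these compounds alone, compound 1 is now the only member with a number, and the aryl groups of compound 2 and compound 3 both end at the limit: the limit of > 10000 nM in this assay, at which 2 of the 3 values shown sit.

The aryl groups of compound 2 and compound 3 cannot be ordered against each other, and the step does not separate the loss of the chlorine from the change of ring. From the compounds shown here alone, whether an unsubstituted phenyl, a 2-chlorophenyl or a pyridin-3-yl without the chlorine on the same carbon keeps a number remains open.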